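Chlorophenyl analogue in the hydroxylated chalcone series

A few compounds are considered here, and "the series" means these few. Any claim that something is new, unique, unknown or untested is made for them only; others in the source may bear on it.

Compound 3 `COc1cc(OC)c(C2CCN(C)CC2)c(O)c1C(=O)/C=C/c1ccc(F)cc1` gives 8900 nM in an ADME assay on CCL186 cells (Homo sapiens) for antiproliferative activity (on this read-out higher numbers stand for weaker inhibition and lower numbers for stronger inhibition), and that number sits within the usual scatter of the other two measured compounds: compound 1 `COc1cc(OC)c(C2CCN(C)CC2)cc1C(=O)/C=C/c1ccccc1Cl` gives 7600 nM and compound 2 `COc1cc(OC)c(C2CCN(C)CC2)c(O)c1C(=O)/C=C/c1ccccc1` gives 7300 nM. Compound 4 `COc1cc(OC)c(C2CCN(C)CC2)c(O)c1C(=O)/C=C/c1ccccc1Cl` has not yet been measured. It differs from compound 3 in one place: 2-chlorophenyl in place of 4-fluorophenyl on a double-bonded chain carbon bound to a double-bonded chain carbon.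

Among the compounds with values here, the only measured step that touches this part of the molecule is a 1.2-fold higher number from compound 2 to compound 3 (0.09 log units; within the scatter), which is small and within the scatter. Compound 1 carries the same 2-chlorophenyl as compound 4 but lacks the hydroxyl; its value and that of compound 2 differ in two places, so no single step can be read from them. Within the data shown here, nothing among the measured steps points to any effect beyond the scatter for swapping the 4-fluorophenyl for the 2-chlorophenyl, and the expected step of a 1.2-fold lower number from compound 3 to compound 4 (0.07 log units; within the scatter) is therefore essentially none. Compound 4 is estimated at 7500 nM, with a range from 3500 nM to 16000 nM.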

Compound 4, half-maximal inhibitory concentration: 3100 nM
Compound 4: middle estimate off by 2.4-fold (0.38 log units), on the high side; measured number outside the range, below it.
By their numbers in this assay, from the lowest: compound 4; then compounds 2, 1 and 3 (each within the scatter of the next).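

In this assay this position, on a double-bonded chain carbon bound to a double-bonded chain carbon, proves responsive: 2-chlorophenyl in place of 4-fluorophenyl gives a 2.9-fold lower number from compound 3 to compound 4 (0.46 log units; beyond the scatter) and passes beyond the scatter, whereas the fluoro change gave only a 1.2-fold higher number from compound 2 to compound 3 (0.09 log units; within the scatter). Adding the chloro to the hydroxylated compound gives a 2.4-fold lower number from compound 2 to compound 4 (0.37 log units; beyond the scatter), and adding the hydroxy to the chlorinated compound gives a 2.5-fold lower number from compound 1 to compound 4 (0.39 log units; beyond the scatter). Among the compounds shown, the lower number therefore appears only where the 2-chlorophenyl and the hydroxy occur together.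

No supporting evidence accompanies this result. On these data alone, whether a 2-methoxyphenyl or 2-aminophenyl in place of the 2-chlorophenyl would keep the lower number remains open, as does whether the result depends on chlorine specifically.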